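Chloro to fluoro swap in a series of limits

This account rests on a few compounds, and the source may have more. Where it says the series, first, only, none or still open, it means among the compounds named here.

Measured in an ADME assay on MT4 cells (Homo sapiens) for cytotoxicity, read by MTT assay; a higher number here means that more compound is tolerated, a lower number that less compound is tolerated:
- compound 1 `O=C(CSc1nc(Cc2c(F)cccc2Cl)cc(=O)[nH]1)c1ccccc1`: > 13000 nM, a limit
- compound 2 `CC(C)c1c(Cc2c(F)cccc2Cl)nc(SCC(=O)c2ccccc2)[nH]c1=O`: > 12000 nM, a limit
- compound 3 `CC(C)c1c(Cc2c(F)cccc2Cl)nc(SCC(=O)c2ccc(F)cc2)[nH]c1=O`: > 56000 nM, a limit

Compound 2 has only a limit and no number, as do the other two compounds, so it cannot be ranked among them. Compound 4 `CC(C)c1c(Cc2c(F)cccc2F)nc(SCC(=O)c2ccccc2)[nH]c1=O` differs from compound 2 by fluoro in place of chloro on an aromatic carbon, which turns 2-chloro-6-fluorobenzyl into 2,6-difluorobenzyl. For the measured compounds named here, no measured step covers this swap. The two nearest are a step that the two limits leave unreadable from compound 1 to compound 2 and a step that the two limits leave unreadable from compound 2 to compound 3, and neither gives a size. The estimated step that the limit leaves unreadable from compound 2 to compound 4 therefore rests on no readable step, and no firm direction is expected in this assay. Compound 4 is estimated at 25000 nM, with an expected range of 9000 nM to 70000 nM.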

Compound 4, half-maximal cytotoxic concentration: > 60000 nM
Compound 4: only a limit was reported (the forecaster's own chance of this, stated with the estimate: 70%); middle value at least 2.4-fold (0.38 log units) from the limit.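

In this assay, for the compounds shown here, compound 2 and compound 4 both stand only as limits, so no step between them can be read. From the compounds shown here alone, whether fluoro in place of chloro shifts the tolerated concentration at all remains open.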